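Compound 3 Gains a Second Trifluoromethyl Group

The source may report more compounds than this note shows. Statements on the series, on what has been measured and on what is new or still open speak of the compounds shown alone.

Of the compounds shown here, three have so far been tested in an ADME assay on cells (Macrophage, Mus musculus) for cytotoxicity, read by resazurin assay, with a stated time of 3 days (on this read-out lower numbers stand for stronger inhibition and higher numbers for weaker inhibition), and all three have a measured number. Compound 1 (`O=S(=O)(Nc1cc(C(F)(F)F)cc(C(F)(F)F)c1)c1cc(Cl)ccc1O`) gives 23000 nM as its result. Compound 2 (`O=C(Nc1cccc(C(F)(F)F)c1)c1cc(Cl)ccc1O`) gives 5900 nM in the same test. Compound 3 (`O=C(Nc1ccc(C(F)(F)F)cc1)c1cc(Cl)ccc1O`) gives 2800 nM and so has the lowest number of the three, with its gap to each of the others lying beyond the usual scatter.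

Compound 4 (`O=C(Nc1ccc(C(F)(F)F)c(C(F)(F)F)c1)c1cc(Cl)ccc1O`) has not yet been measured. It differs from compound 3 in one place (trifluoromethyl in place of hydrogen on an aromatic carbon): trifluoromethyl in place of hydrogen on an aromatic carbon, ortho to a trifluoromethyl group.

Among the compounds with values here, no two measured compounds differ in only one place, so the data give no direct size for this change. Compound 1 also carries two trifluoromethyl groups and gives 23000 nM as the highest number here, but it has a sulfonamide link where the others have an amide, so it is a weak guide. A small move towards a lower number is expected, one that stays within the scatter. The expected step is a 1.4-fold lower number from compound 3 to compound 4 (0.15 log units; within the scatter) in this assay on this reasoning. The estimate for compound 4 is 2000 nM with an expected range of 700 nM to 6000 nM once it is measured.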

Compound 4, half-maximal inhibitory concentration: 4900 nM
Estimate against measurement, compound 4: 2.5-fold (0.39 log units) below; low and high end bracket the measured number.
By their numbers in this assay, from the lowest: compounds 3, 4 and 2 (each within the scatter of the next, the first and the last beyond it); then compound 1.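

Putting a trifluoromethyl group in place of hydrogen on this aromatic carbon, ortho to a trifluoromethyl group, gives the first direct measure of this change in this assay: the result is a 1.8-fold higher number from compound 3 to compound 4 (0.24 log units; within the scatter). Approached from the other single-trifluoromethyl amide, the change gives a 1.2-fold lower number from compound 2 to compound 4 (0.08 log units; within the scatter), so in both comparisons a second trifluoromethyl group leaves the read-out within the normal variation between repeat measurements, and neither step shows a real shift in either direction. No measured property shown here explains these numbers.

Within the data shown here, these two steps describe only one added group, in one amide series and one cell test, so they cannot show whether a different group on the same aromatic carbon, such as a nitrile, an amine, a carboxylic acid or a longer chain, would give a clearly different number. Also open is whether a second trifluoromethyl group would behave the same way with a sulfonamide link in place of the amide, since the one sulfonamide shown has no single-change partner for comparison.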